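A few compounds are considered here, and "the series" means these few. Any claim that something is new, unique, unknown or untested is made for them only; others in the source may bear on it.

In a functional assay on SW-620 cells (Homo sapiens) for antiproliferative activity, read by MTT assay, with a stated time of 24 h (a higher number here means a weaker inhibitor, a lower number a stronger inhibitor), compound 2, `COc1ccc(C(=O)/C=C/c2ccc([N+](=O)[O-])cc2)c2c1C=CC(C)(C)O2`, gives 3520 nM. Compound 1, `COc1ccc(C(=O)/C=C/c2ccc(-n3ccnc3)cc2)c2c1C=CC(C)(C)O2`, gives > 10000 nM, which is a limit of the assay rather than a number. Compound 3, `COc1ccc(C(=O)/C=C/c2ccsc2)c2c1C=CC(C)(C)O2`, likewise gives > 10000 nM, again a limit and not a number. Compound 3 therefore stands among the weaker compounds on the numbers shown, with the limit of > 10000 nM in this assay, at which 2 of the 3 values shown sit, marking where two of the three values sit.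

The step to compound 4, `COc1ccc(C(=O)/C=C/c2ccc(O)c(Br)c2)c2c1C=CC(C)(C)O2`, changes only the aromatic group on the chain: 3-bromo-4-hydroxyphenyl in place of thiophen-3-yl on a double-bonded chain carbon bound to a double-bonded chain carbon.

Among the compounds with values here, two measured steps bear on this place. Within the data shown here, the step of an at least 2.8-fold lower number from compound 1 to compound 2 (0.45 log units; beyond the scatter) and the step of an at least 2.8-fold higher number from compound 2 to compound 3 (0.45 log units; beyond the scatter) both show that the aromatic group on the double-bonded chain carbon moves the read-out beyond the scatter, and that a six-membered ring of carbon only carrying a nitro group gave the lowest number so far, while the thiophen-3-yl of compound 3 returned to the limit. A six-membered ring of carbon only with a 3-bromo-4-hydroxyphenyl pattern is expected to fall between those two cases, so a modest lowering is expected in this assay.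

Compound 4 is therefore estimated at 5000 nM, with a range from 1500 nM to 15000 nM. This estimate means an expected step of an at least 2.0-fold lower number from compound 3 to compound 4 (0.30 log units; that floor lies within the scatter).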

Compound 4, half-maximal inhibitory concentration: > 10000 nM
Compound 4: no number, only a limit (the forecaster's own chance of this, stated with the estimate: 40%); at least 2.0-fold (0.30 log units) between middle value and limit.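

In this assay the result is an at least 2.8-fold higher number from compound 2 to compound 4 (0.45 log units; beyond the scatter), so the 3-bromo-4-hydroxyphenyl group does not match the 4-nitrophenyl group at this place on a double-bonded chain carbon. Among the compounds shown, a six-membered aromatic ring of carbon only no longer goes with a readable number by itself: compound 2, which gives 3520 nM, remains the only one of the four to give a number rather than a limit, and compound 1 and compound 4 both carry such a ring. Compound 3 and compound 4 both stand at a limit, so the step between them cannot be read, and the series now gathers at one end of the scale: the limit of > 10000 nM in this assay, at which 3 of the 4 values shown sit.

The limits leave open how far compound 1, compound 3 and compound 4 differ from one another, and whether the bromine or the hydroxyl of compound 4 matters more at this place. As far as these compounds go, it also remains open whether an amine or a carboxylic acid in the position of the nitro group on the same ring would give a number like that of compound 2, or would stay at the limit.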